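A few compounds are considered here, and "the series" means these few. Any claim that something is new, unique, unknown or untested is made for them only; others in the source may bear on it.

Measured so far:
Compound 1, `Nc1ccccc1NC(=O)c1ccc(CSC(=S)N2CCN(Cc3ccccn3)CC2)cc1`, gives 65.2% in a functional assay on MGC-803 cells (Homo sapiens) for antiproliferative activity, read by CCK-8 assay, with a stated time of 72 h, tested at 8 uM; a lower number here means a weaker effect, a higher number a stronger effect of the compound at the concentration tested.
Compound 2, `Nc1ccccc1NC(=O)c1ccc(CSC(=S)N(Cc2ccccc2)Cc2ccccc2)cc1`, gives 30.7% in this assay.

Among the measured compounds shown here, of these two numbers, compound 1 stands highest; the only other compound, compound 2, lies lower by a gap beyond the usual scatter. For the measured compounds named here, no pair of measured compounds differing in just one place is available, so nothing here shows how much a small change at this end of the molecule moves the read-out.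

Compound 3, `Nc1ccccc1NC(=O)c1ccc(CSC(=S)N2CCN(Cc3cccnc3)CC2)cc1`, has not yet been measured. It differs from compound 1 in one place: pyridin-3-yl in place of pyridin-2-yl on a saturated chain carbon bound to an amine nitrogen in a ring. The same atoms are simply joined differently, so the change is a small one. Going by the values given here, with no comparable step to draw on, a modest step is expected in this assay, more likely downward than upward, and possibly not beyond the scatter at all. Compound 3 is therefore estimated to give about 57%, with a range from 40% to 74%. The expected step is a number 8.2 percentage points lower from compound 1 to compound 3 (within the scatter).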

Compound 3, a percentage reported as inhibition, at one concentration (the size of the read-out at that concentration, not a potency): 64.6%
Estimate against measurement, compound 3: 7.6 percentage points below; measured number inside the range.
By their numbers in this assay, from the lowest: compound 2; then compounds 3 and 1 (each within the scatter of the next).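

In this assay, exchanging pyridin-2-yl for pyridin-3-yl on a saturated chain carbon bound to an amine nitrogen in a ring gives a number 0.6 percentage points lower from compound 1 to compound 3 (within the scatter). Among the compounds shown here, this is the first comparison here of two compounds that differ in one place, and at this single concentration the read-out does not tell the two groups apart, so the ring nitrogen can occupy either of these two arrangements without a measurable difference. No measurement at hand explains why the two compounds read alike.

Still open, on these data alone, is how the read-out responds at this place to pyridin-4-yl or to a plain phenyl ring, which has no ring nitrogen at all. As far as these compounds go, a longer chain, such as (pyridin-3-yl)ethyl in place of (pyridin-3-yl)methyl, is equally open.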